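Ether truncation to hydroxy in a weak bicyclic series

A few compounds are considered here, and "the series" means these few. Any claim that something is new, unique, unknown or untested is made for them only; others in the source may bear on it.

Compound 1 `CCO[C@H]1CC[C@H]2CCN(C)[C@H]2C1` and compound 2 `COCCO[C@H]1CC[C@H]2CCN(C)[C@H]2C1` share one core. In an assay on HEK293 cells for displacement of a labelled ligand from Neuronal acetylcholine receptor; alpha4/beta2 (Rattus norvegicus), with a stated time of 4 h (on this read-out higher numbers stand for weaker inhibition and lower numbers for stronger inhibition), compound 1 gives 300000 nM and compound 2 gives 300000 nM; the step of no change at the digits printed from compound 1 to compound 2 (within the scatter) lies within the scatter. Compound 3 `CN1CC[C@@H]2CC[C@H](O)C[C@@H]21` differs from compound 2 by hydrogen in place of 2-methoxyethyl on an oxygen on a saturated carbon. Within the data shown here, only one measured step bears on this change, and it is indirect: lengthening the ether chain by a methoxy gave no change at the digits printed from compound 1 to compound 2 (within the scatter), so removing the whole chain is expected to move little. The step from compound 2 to compound 3 is expected as no change at the digits printed from compound 2 to compound 3 (within the scatter). Compound 3 is estimated at 300000 nM, within 100000 nM to 1000000 nM.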

Compound 3, inhibition constant: > 300000 nM
Compound 3 ended at the assay's limit; the forecaster's own chance of this, stated with the estimate: 35%; the middle value sits exactly at the limit.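

The value of compound 3 is a limit of the assay and not a number, so the steps to it from compound 1 and compound 2 cannot be read for size. They give direction only: taking ethyl off this oxygen, leaving hydroxy, gave a number no lower from compound 1 to compound 3 (the limit leaves the size open) in this assay. Hydrogen on this oxygen therefore shows no gain over either ether, and any reading of this result is bounded by the limit: the limit of > 300000 nM in this assay, at which 1 of the 3 values shown sits.

Open, on these data alone, is whether a benzyl group on this oxygen, or an amine in its place, would give a number clear of the limit in this assay, where taking 2-methoxyethyl off this oxygen gave a number no lower from compound 2 to compound 3 (the limit leaves the size open).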